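A Methoxy-for-Fluoro Swap Tested for Cell Tolerance

This account rests on a few compounds, and the source may have more. Where it says the series, first, only, none or still open, it means among the compounds named here.

Compound 1 `CCc1c(Cc2c(Cl)cccc2Cl)nc(SCC(=O)c2ccc(F)cc2)[nH]c1=O` carries a fluoro group on its outer aromatic ring. In an ADME assay on MT4 cells (Homo sapiens) for cytotoxicity, read by MTT assay (a higher number here means that more compound is tolerated, a lower number that less compound is tolerated), compound 1 gives a value that is a limit of the assay, > 55000 nM. Compound 2 `CCc1c(Cc2c(Cl)cccc2Cl)nc(SCC(=O)c2ccc(OC)cc2)[nH]c1=O` differs from compound 1 by methoxy in place of fluoro on an aromatic carbon. In this assay compound 2 also gives a limit, > 54000 nM. The step that the two limits leave unreadable from compound 1 to compound 2 therefore cannot be sized; the measurements stop at the limit of > 54000 nM in this assay, at which 2 of the 3 values shown sit, and (the limit of > 55000 nM in this assay, at which 1 of the 3 values shown sits). Compound 3 `CC(C)c1c(Cc2c(Cl)cccc2Cl)nc(SCC(=O)c2ccc(F)cc2)[nH]c1=O` differs from compound 1 by methyl in place of hydrogen on a saturated chain carbon bound to an aromatic carbon and a saturated chain carbon, a change on the shared core. In this assay compound 3 gives a limit, > 54000 nM. Compound 4 `COc1ccc(C(=O)CSc2nc(Cc3c(Cl)cccc3Cl)c(C(C)C)c(=O)[nH]2)cc1` has not been tested; it differs from compound 3 by methoxy in place of fluoro on an aromatic carbon, the same change as from compound 1 to compound 2, at the same place. Because a step that the two limits leave unreadable from compound 1 to compound 2 could not be read, and because the limit of > 54000 nM in this assay, at which 2 of the 3 values shown sit, holds two of the three values shown, the expected step is a step that the limit leaves unreadable from compound 3 to compound 4, with no readable movement in either direction. Compound 4 is therefore expected to give 60000 nM, most likely once more as a limit rather than a number.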

Compound 4, half-maximal cytotoxic concentration: > 14000 nM
Compound 4: a limit, no number; the forecaster's own chance of this, stated with the estimate: 85%; the middle value does not contradict the limit.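

In this assay compound 4 gives only a limit, > 14000 nM, and not a number. Compound 2 and compound 3 also stand at limits, so neither step to compound 4 can be read. What stays open is the concentration at which any of these compounds stops being tolerated, and whether methoxy in place of fluoro changes that concentration at all.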